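A few compounds are considered here, and "the series" means these few. Any claim that something is new, unique, unknown or untested is made for them only; others in the source may bear on it.

Values in a functional assay on the whole organism for antagonist activity, with Mus musculus as the target; on this read-out lower numbers stand for an effect already at smaller amounts and higher numbers for an effect only at larger amounts of compound:
- Compound 1 `CCCCCCC(=O)NCC(=O)N(C)c1ccc(Cl)cc1C(=O)c1ccccc1Cl`: 1.9 mg/kg
- Compound 2 `CCCC(=O)NCC(=O)N(C)c1ccc(Cl)cc1C(=O)c1ccccc1Cl`: 0.98 mg/kg
- Compound 3 `CCCCCCCCCCCCCCCC(=O)NCC(=O)N(C)c1ccc(Cl)cc1C(=O)c1ccccc1Cl`: > 100 mg/kg

Compound 3 stands apart from the other two, and its entry is a limit of the assay and not a number: the limit of > 100 mg/kg in this assay, at which 1 of the 3 values shown sits.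

Compound 4 `CCCCC(=O)NCC(=O)N(C)c1ccc(Cl)cc1C(=O)c1ccccc1Cl` has not yet been measured. The change from compound 3 is hydrogen in place of undecyl on a saturated chain carbon, four bonds along the chain from a carbonyl carbon. In words, hydrogen takes the place of undecyl on a saturated chain carbon, four bonds along the chain from a carbonyl carbon. The result is a chain longer than that of compound 2 and shorter than that of compound 1.

Within the data shown here, two measured steps bear most directly on this change, and both run the opposite way, towards the long chain: an at least 100-fold higher number from compound 2 to compound 3 (2.00 log units; beyond the scatter), and an at least 52-fold higher number from compound 1 to compound 3 (1.72 log units; beyond the scatter). Both are large. The third step, a 1.9-fold lower number from compound 1 to compound 2 (0.29 log units; within the scatter), shows no real difference between the two shorter chains. Compound 4 is therefore expected to return to their level, with a large drop in the number. The expected step is an at least 76-fold lower number from compound 3 to compound 4 (1.88 log units; beyond the scatter). For compound 4 the estimated value is 1.3 mg/kg, with an expected range of 0.6 mg/kg to 3 mg/kg.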

Compound 4, dose for half-maximal effect: 1.3 mg/kg
For compound 4 middle estimate and measured number coincide at the digits printed, within the range that was stated.
By their numbers in this assay, from the lowest: compounds 2, 4 and 1 (each within the scatter of the next). At a limit, above all of these: compound 3.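

Compound 4 shows that the short chains sit on a single level in this series, with a 1.3-fold higher number from compound 2 to compound 4 (0.12 log units; within the scatter) and a 1.5-fold lower number from compound 1 to compound 4 (0.16 log units; within the scatter), so adding or removing these few chain carbons makes no difference that can be told apart. Placing hydrogen where undecyl stood gives an at least 76-fold lower number from compound 3 to compound 4 (1.88 log units; beyond the scatter), which shows that the large rise belongs to the much longer chain alone, and compound 3 is the one compound that goes against the flat picture. The true size of that step stays unknown because compound 3 has a limit and not a number: the limit of > 100 mg/kg in this assay, at which 1 of the 4 values shown sits.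

The compounds shown do not tell at what length, on the way from the chain of compound 1 to the far longer chain of compound 3, the number begins to rise, or whether it does so sharply or in stages. They also do not tell what an amine or a carboxylic acid would do on a saturated chain carbon, four bonds along the chain from a carbonyl carbon, where only hydrogen and plain carbon chains are seen so far.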